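The source may hold more compounds than are shown below. What is called first, only, known or untested is meant among the compounds shown, and "the series" means these compounds.

Three compounds share one core and differ only in the group on the saturated chain carbon bound to a sulfur. Compound 1 `C/C(C#Cc1ccccc1)=N\N/C(N)=N/S(=O)(=O)c1cc(C)c(Cl)cc1SCc1ccccc1` gives, in a functional assay on HCT-116 cells (Homo sapiens) for antiproliferative activity, read by MTT assay, with a stated time of 72 h (on this read-out higher numbers stand for weaker inhibition and lower numbers for stronger inhibition), a value of 10000 nM. Compound 2 `C/C(C#Cc1ccccc1)=N\N/C(N)=N/S(=O)(=O)c1cc(C)c(Cl)cc1SCc1ccc(C)cc1` gives 13000 nM, and compound 3 `C/C(C#Cc1ccccc1)=N\N/C(N)=N/S(=O)(=O)c1cc(C)c(Cl)cc1SCc1ccc(Cl)cc1` gives 10000 nM. The steps among them are all small: a 1.3-fold higher number from compound 1 to compound 2 (0.11 log units; within the scatter), no change at the digits printed from compound 1 to compound 3 (within the scatter) and a 1.3-fold lower number from compound 2 to compound 3 (0.11 log units; within the scatter). Compound 3 thus stands level with compound 1, the two together holding the lowest numbers of the three, with compound 2 at a gap that still lies within the scatter.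

Compound 4 `C/C(C#Cc1ccccc1)=N\N/C(N)=N/S(=O)(=O)c1cc(C)c(Cl)cc1SCc1cccc2ccccc12` has not yet been measured. It differs from compound 3 by naphthalen-1-yl in place of 4-chlorophenyl on a saturated chain carbon bound to a sulfur. The measured steps bear on this change only in part: they show that a methyl or a chloro on an aromatic carbon of this group shifted the number by no more than the scatter, whereas the exchange of 4-chlorophenyl for naphthalen-1-yl is not covered by any measured pair. Since every measured step around compound 3 fell within the scatter, the step expected here is no change at the digits printed from compound 3 to compound 4 (within the scatter), with no direction claimed beyond the scatter, though the range is kept wide for an untested change of this kind. Compound 4 is therefore estimated to give 10000 nM, between 3500 nM and 30000 nM.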

Compound 4, half-maximal inhibitory concentration: 105000 nM
The estimate for compound 4 lay 11-fold (1.02 log units) below the measured number, and the stated range ends below it.
By their numbers in this assay, from the lowest: compounds 1, 3 and 2 (each within the scatter of the next); then compound 4.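

In this assay, within the data shown here, the saturated chain carbon bound to a sulfur proved not to be indifferent to the group it carries, which the earlier compounds could not show, since a methyl or a chloro on the phenyl ring had moved the number only within the scatter. Replacing the single six-membered aromatic ring with the two of naphthalen-1-yl gave an 11-fold higher number from compound 3 to compound 4 (1.02 log units; beyond the scatter), and the same exchange gave an 11-fold higher number from compound 1 to compound 4 (1.02 log units; beyond the scatter) and an 8.1-fold higher number from compound 2 to compound 4 (0.91 log units; beyond the scatter), so inhibition weakened clearly from all three earlier compounds, whichever of the three groups was replaced. Nothing at hand bears on what lies behind this shift.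

The compounds shown leave open whether the weaker inhibition goes with the second aromatic ring as such or with something particular to naphthalen-1-yl, a question that a comparison with a cyclohexyl or a pyridinyl group in the same place would begin to address. They also leave open whether any group here can bring the number clearly below that of compound 1, 10000 nM, for instance a 2-phenylethyl chain in place of the benzyl group.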